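The compounds below may be only part of what the source reports. "The series", "measured", "known", "first", "only" and "open" are said of these compounds alone.

Of the compounds shown here, two have so far been measured in a functional assay on NCI-H1975 cells (Homo sapiens) for inhibition, read by MTT assay, with a stated time of 72 h; on this read-out higher numbers stand for weaker inhibition and lower numbers for stronger inhibition. Compound 1 `O=C(CSc1nc(Nc2ccccc2)c2ccccc2n1)Nc1ccccc1F` gives 9350 nM, and compound 2 `C=CC(=O)Nc1cccc(NC(=O)CSc2nc(Nc3ccccc3)c3ccccc3n2)c1` gives 8120 nM. Among the compounds with values here, compound 2 has the lower of the two numbers, but the gap to its only neighbour lies within the scatter. Within the data shown here, the single measured step reads a 1.2-fold lower number from compound 1 to compound 2 (0.06 log units; within the scatter), and it alters the group on the amide-type nitrogen. Compound 3 `C=CC(=O)Nc1cccc(NC(=O)CSc2nc(Nc3cccc(Br)c3)c3ccccc3n2)c1` is not yet measured. It differs from compound 2 by bromo in place of hydrogen on an aromatic carbon, a change on the anilino side of the shared core. Among the measured compounds shown here, no measured step touches that part of the structure, so nothing measured points to a gain or a loss there. The expected step is therefore a 1.0-fold lower number from compound 2 to compound 3 (0.01 log units; within the scatter), nothing beyond the scatter. The estimate for compound 3 in this assay is 8000 nM, with a range from 3000 nM to 20000 nM.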

Compound 3, half-maximal inhibitory concentration: 12100 nM
The estimate for compound 3 lay 1.5-fold (0.18 log units) below the measured number; low and high end bracket the measured number.
By their numbers in this assay, from the lowest: compounds 2, 1 and 3 (each within the scatter of the next).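

Within the data shown here, the step of a 1.5-fold higher number from compound 2 to compound 3 (0.17 log units; within the scatter) in this assay is the first measured change on the anilino side of the shared core. It shows that at this place, on an aromatic carbon meta to a large group, a single bromine atom in place of hydrogen leaves the read-out within the usual spread of repeated measurements, so neither a gain nor a loss can be claimed for it. No measurement at hand offers an explanation for this result.

As far as these compounds go, whether a different group on this same carbon, such as an amine, a methoxy group or a carboxylic acid, would shift the number beyond that spread remains open. From the compounds shown here alone, it is also open whether bromo on another carbon of this ring would give a similar result.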